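Swapping bromo for methyl on a second core

The source may report more compounds than this note shows. Statements on the series, on what has been measured and on what is new or still open speak of the compounds shown alone.

Of the compounds shown here, three have been measured, and a fourth awaits measurement. Compound 1 `COc1ccccc1/C=C(\C(=O)c1ccc(Cl)cc1)S(=O)(=O)c1ccc(C)cc1` and compound 2 `COc1ccccc1/C=C(\C(=O)c1ccc(Cl)cc1)S(=O)(=O)c1ccc(Br)cc1` share a core; compound 3 `COc1ccc(/C=C(\C(=O)c2ccc(Cl)cc2)S(=O)(=O)c2ccc(Br)cc2)cc1O` and compound 4 `COc1ccc(/C=C(\C(=O)c2ccc(Cl)cc2)S(=O)(=O)c2ccc(C)cc2)cc1O` share another. The two cores differ in that (3-hydroxy-4-methoxyphenyl in place of 2-methoxyphenyl on a double-bonded chain carbon bound to a double-bonded chain carbon); across that difference the number moved no change at the digits printed from compound 2 to compound 3 (within the scatter).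

In a functional assay on DU-145 cells (Homo sapiens) for inhibition, read by trypan blue exclusion, with a stated time of 96 h (on this read-out lower numbers stand for stronger inhibition of growth and higher numbers for weaker inhibition of growth), compound 1 gives 1000 nM, compound 2 gives 10000 nM, and compound 3 gives 10000 nM.

Within the first core the change from compound 2 to compound 1 is methyl in place of bromo on an aromatic carbon, and it moved the number a 10-fold lower number from compound 2 to compound 1 (1.00 log units; beyond the scatter). Within the second core the change from compound 3 to compound 4 is methyl in place of bromo on an aromatic carbon; the place of the change is described in the same words for both pairs, so it is the same change on a different core.

Among the compounds with values here, since the same change is made on a core that shows no change at the digits printed from compound 2 to compound 3 (within the scatter), the step is expected to be about as large: a 10-fold lower number from compound 3 to compound 4 (1.00 log units; beyond the scatter), because the step of a 10-fold lower number from compound 2 to compound 1 (1.00 log units; beyond the scatter) is the only instance measured. Compound 4 is thus estimated at 1000 nM, between 400 nM and 3000 nM.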

Compound 4, concentration for 50% growth inhibition: 1000 nM
Compound 4: the middle estimate sits on the measured number at the digits printed, and the stated range covers the measured number.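

In this assay, putting methyl in place of bromo on the second core gave a 10-fold lower number from compound 3 to compound 4 (1.00 log units; beyond the scatter), and this step matches the one seen on the first core: the same change on two cores in this assay, a 10-fold lower number (1.00 log units; beyond the scatter) from compound 2 to compound 1 and a 10-fold lower number (1.00 log units; beyond the scatter) from compound 3 to compound 4, 1.0-fold (0.00 log units) apart, within the scatter of two such steps

The other single change, 3-hydroxy-4-methoxyphenyl in place of 2-methoxyphenyl, now reads the same with methyl as with bromo, giving no change at the digits printed from compound 1 to compound 4 (within the scatter): the same change on two cores in this assay, no change at the digits printed (within the scatter) from compound 2 to compound 3 and no change at the digits printed (within the scatter) from compound 1 to compound 4, 1.0-fold (0.00 log units) apart, within the scatter of two such steps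

Together these pairs show that, in this assay, the bromo-to-methyl change carried from one core to the other at full size, while the difference between the cores left no mark on the number; they do not show why methyl gives the lower number, nor that the same step would appear on any core beyond these two.

The compounds shown leave open what other groups would do in the place held by bromo and methyl, such as an amine, a carboxylic acid or a longer chain. They also leave open whether the same step would appear in other cell lines or with other read-outs.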